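Swapping a Nitrile for Chlorine and Methyl on a Weak Inhibitor

This account rests on a few compounds, and the source may have more. Where it says the series, first, only, none or still open, it means among the compounds named here.

Going by the values given here, compound 1 `N#Cc1ccccc1COc1ccccc1C(=O)Nc1cccnc1` gives 31800 nM in an assay on lysate for inhibition of phosphatidylcholine:ceramide cholinephosphotransferase 2 (Homo sapiens), read by HPLC, with stated times of 30 min and 2 h (on this read-out lower numbers stand for stronger inhibition and higher numbers for weaker inhibition), the lowest of the two numbers measured so far. Compound 2 `N#Cc1cccc(COc2ccccc2C(=O)Nc2cccnc2)c1` gives 60700 nM in this assay, and the step of a 1.9-fold higher number from compound 1 to compound 2 (0.28 log units; within the scatter) stays within the scatter. Compound 3 `Cc1c(Cl)cccc1COc1ccccc1C(=O)Nc1cccnc1` differs from compound 1 in one place: 3-chloro-2-methylphenyl in place of 2-cyanophenyl on a saturated chain carbon bound to an oxygen on an aromatic ring. Among the compounds with values here, no measured step exchanges a nitrile for chlorine and methyl; the only step available, a 1.9-fold higher number from compound 1 to compound 2 (0.28 log units; within the scatter), merely moves the nitrile and lies within the scatter. Compound 3 is therefore expected to show no step beyond the scatter, a 1.0-fold higher number from compound 1 to compound 3 (0.00 log units; within the scatter). The estimate for compound 3 is 32000 nM, within 10000 nM to 100000 nM.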

Compound 3, half-maximal inhibitory concentration: 3800 nM
For compound 3 the middle estimate is 8.4-fold (0.93 log units) above the measured one; the measured number lies below the stated range.
By their numbers in this assay, from the lowest: compound 3; then compounds 1 and 2 (each within the scatter of the next).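

In this assay this position proves sensitive to the group it carries: moving the nitrile stayed within the scatter, but 3-chloro-2-methylphenyl gives an 8.4-fold lower number from compound 1 to compound 3 (0.92 log units; beyond the scatter) and also a 16-fold lower number from compound 2 to compound 3 (1.20 log units; beyond the scatter) in the same series. A phenyl ring without a nitrile can therefore give the lowest number of the three on the shared core.

Compound 3 brings in chlorine and methyl together, so the compounds shown leave open whether 3-chlorophenyl or 2-methylphenyl alone would account for the step. Nothing available explains the drop.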